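A few compounds are considered here, and "the series" means these few. Any claim that something is new, unique, unknown or untested is made for them only; others in the source may bear on it.

Measured so far in a functional assay on KB cells (Homo sapiens) for antiproliferative activity, read by sulforhodamine B assay, with a stated time of 72 h; a lower number here means a stronger inhibitor of growth, a higher number a weaker inhibitor of growth:

Compound 1, `COC(=O)c1cccc(CSc2ccc3c(C)cc(=O)oc3c2)c1`, gives 2060 nM.
Compound 2, `CCc1cc(=O)c2ccc(OCc3cccc(C(F)(F)F)c3)c(C)c2o1`, gives only a limit of the assay, > 27600 nM.
Compound 3, `CCc1cc(=O)c2ccc(OC)c(CBr)c2o1`, gives only a limit of the assay, > 33600 nM.

Compound 3 therefore stands without a proper number in this assay: its result is a limit, and of the three values shown, one other is a limit as well (the limit of > 27600 nM in this assay, at which 1 of the 3 values shown sits, (the limit of > 33600 nM in this assay, at which 1 of the 3 values shown sits)). For the measured compounds named here, only compound 1 gives a real number, and no step between two measured compounds that differ in a single place is available to learn from.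

Compound 4, `CCOc1ccc2c(=O)cc(CC)oc2c1CBr`, is made from compound 3 by one change: methyl in place of hydrogen on a saturated chain carbon bound to an oxygen on an aromatic ring. In words, a methyl in place of hydrogen on a saturated chain carbon bound to an oxygen on an aromatic ring, so the methoxy becomes an ethoxy.

Since compound 3 sits at a limit, the step from compound 3 to compound 4 is expected to be none beyond the scatter, a step that the limit leaves unreadable from compound 3 to compound 4. Compound 4 is expected to land around 40000 nM, in the range 15000 nM to 150000 nM, most likely again reported only as a limit.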

Compound 4, concentration for 50% growth inhibition: > 32100 nM
Compound 4 ended at the assay's limit; the forecaster's own chance of this, stated with the estimate: 75%; the middle value is on the limit's open side.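

Compound 3 and compound 4 each give only a limit of the assay in this assay, and the step between them cannot be read. The compounds shown leave open whether going from methoxy to ethoxy changes growth inhibition at all.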